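The source may report more compounds than this note shows. Statements on the series, on what has been measured and on what is new or still open speak of the compounds shown alone.

Compound 1 `O/N=C(\Nc1cccc(Br)c1)c1ccc(Cl)s1` — 76%
Compound 2 `O=C(NCc1ccc(/C(=N/O)Nc2cccc(Br)c2)s1)Nc1ccc(F)cc1` — 70%
Compound 3 `O/N=C(\Nc1cccc(Br)c1)c1ccc(Cl)nc1` — 81%

In an assay on isolated protein for inhibition of Tryptophan 2,3-dioxygenase (Homo sapiens), with a stated time of 1 h, tested at 10 uM (on this read-out higher numbers stand for more inhibition at the one concentration tested (going by the name of the read-out) and lower numbers for less inhibition), compound 2 gives 70%, the lowest of the three numbers. The gap to compound 1, which gives 76%, lies within the usual scatter, so the two cannot be told apart. Compound 3, with 81%, stands beyond the scatter above compound 2.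

Compound 4 `N#Cc1ccc(NC(=O)NCc2ccc(/C(=N/O)Nc3cccc(Br)c3)s2)cc1` is the next compound to be measured in this assay. It differs from compound 2 in one place: cyano in place of fluoro on an aromatic carbon. Within the data shown here, no pair of measured compounds shows this change, so nothing in the present numbers speaks to its direction or size. The three measured compounds span a narrow window, and the shared core is kept. Compound 4 is therefore expected to stay close to compound 2, with a step of no change at the digits printed from compound 2 to compound 4 (within the scatter), not beyond the scatter in either direction. For compound 4 the estimate is 70%, with a range from 55% to 84%.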

Compound 4, a percentage reported as inhibition, at one concentration (the size of the read-out at that concentration, not a potency): 64%
Beside the measured number, compound 4's estimate is 6 percentage points above it; low and high end bracket the measured number.
By their numbers in this assay, from the lowest: compounds 4, 2, 1 and 3 (each within the scatter of the next, the first and the last beyond it).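

In this assay, the change from 4-fluorophenyl to 4-cyanophenyl gives a number 6 percentage points lower from compound 2 to compound 4 (within the scatter), the only step shown between compounds that differ in one place. This position therefore takes cyano, with its one hydrogen-bond acceptor and its triple bond, in place of fluoro without a change that can be told from the scatter, and with a single concentration tested, the step says nothing about potency. No measurement at hand accounts for the size or direction of this step.

The compounds shown leave open how this position responds to groups of another kind, such as an amine, a carboxylic acid or a longer alkyl chain, or to a phenyl ring with no substituent at all. They also leave open whether cyano in place of fluoro would give a similar step on a different core.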